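Ring contraction at the aniline nitrogen in a cytotoxicity series

This account rests on a few compounds, and the source may have more. Where it says the series, first, only, none or still open, it means among the compounds named here.

Compound 1 `CCN(CC)c1ccc(C(F)(F)F)cc1NC(=O)c1cccnc1Cl`: 88400 nM
Compound 2 `O=C(Nc1cc(C(F)(F)F)ccc1N1CCCCC1)c1cccnc1Cl`: "not active" (no number reported)

In a functional assay on Jurkat cells (Homo sapiens) for cytotoxicity, read by MTT assay, with a stated time of 48 h (on this read-out lower numbers stand for stronger inhibition and higher numbers for weaker inhibition), compound 1 gives 88400 nM, a weak result. Compound 2 was reported as "not active" (no number reported) in this assay, so no single number places it on the scale; it can only be said that compound 2 did not reach measurable inhibition where compound 1 did. Going by the values given here, no step between measured compounds is available to guide the next change.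

Compound 3 `O=C(Nc1cc(C(F)(F)F)ccc1N1CCCC1)c1cccnc1Cl` differs from compound 2 by a single change: pyrrolidin-1-yl in place of piperidin-1-yl on an aromatic carbon. With compound 2 giving no number and compound 1 only a weak one, the expected step in this assay is none beyond the usual scatter, and a reported limit rather than a number is the more likely outcome. For compound 3 the expected half-maximal inhibitory concentration is 100000 nM, with a range from 40000 nM to 300000 nM.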

Compound 3, half-maximal inhibitory concentration: "not active" (no number reported)
Compound 3: no number reported; no gap can be computed for the estimate.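

Compound 2 and compound 3 both came back as "not active" in this assay without a number, so no step can be read between them. No measured evidence bears on this result. The compounds shown leave open how far the two rings differ in effect, if at all.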